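This account rests on a few compounds, and the source may have more. Where it says the series, first, only, none or still open, it means among the compounds named here.

Three compounds sharing one core have been examined in a functional assay on HCT-116 cells (Homo sapiens) for inhibition, read by MTT assay, with a stated time of 24 h, tested at 5 uM; a lower number here means less inhibition of growth, a higher number more inhibition of growth at the concentration tested. Compound 1 `CS(=O)(=O)c1ccc(-c2cnc3[nH]cc(-c4nnc(-c5ccncc5)o4)c(=O)c3c2)cc1` gives 5.61% in this assay. Compound 2 `CS(=O)(=O)c1ccc(-c2cnc3[nH]cc(-c4nnc(-c5ccc(Cl)cc5)o4)c(=O)c3c2)cc1` gives 16.4%, and compound 3 `Cc1ccc(-c2nnc(-c3c[nH]c4ncc(-c5ccc(S(C)(=O)=O)cc5)cc4c3=O)o2)cc1` gives 20.4%. Among the three, compound 3 holds the largest number, although the step of a number 4 percentage points higher from compound 2 to compound 3 (within the scatter) lies within the scatter, so compound 3 and compound 2 cannot be told apart; only the step of a number 14.8 percentage points higher from compound 1 to compound 3 (beyond the scatter) is beyond it, as is the step of a number 10.8 percentage points higher from compound 1 to compound 2 (beyond the scatter).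

Compound 4 `Cc1cccc(-c2nnc(-c3c[nH]c4ncc(-c5ccc(S(C)(=O)=O)cc5)cc4c3=O)o2)c1` differs from compound 3 by 3-methylphenyl in place of 4-methylphenyl on an aromatic carbon. Among the compounds with values here, no measured step moves a methyl around the same phenyl ring; the steps from compound 1 exchange the whole aryl group, and the step from compound 2 to compound 3 exchanges one substituent for another at an unchanged position and stays within the scatter. On that basis no step beyond the scatter is expected for a number 2.4 percentage points lower from compound 3 to compound 4 (within the scatter). Compound 4 is therefore estimated to give about 18% in this assay, within a range from 7% to 30%.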

Compound 4, percent growth inhibition at one concentration: 20.4%
Compound 4: the middle estimate sits 2.4 percentage points below what was measured; the range from low to high includes it.
By their numbers in this assay, from the lowest: compound 1; then compounds 2, 3 and 4 (each within the scatter of the next).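

Exchanging 4-methylphenyl for 3-methylphenyl on this aromatic carbon of the five-membered ring gives no change at the digits printed from compound 3 to compound 4 (within the scatter) in this assay, so the two placements of the methyl on the phenyl ring cannot be told apart here. The 3-methylphenyl group gives a number 4 percentage points higher from compound 2 to compound 4 (within the scatter) against 4-chlorophenyl but a number 14.8 percentage points higher from compound 1 to compound 4 (beyond the scatter) against pyridin-4-yl, so compound 1 alone stands apart from the three compounds carrying a substituted phenyl ring. Nothing available explains these results.

As far as these compounds go, it remains open whether an amine, a carboxylic acid or a longer chain such as butyl on that phenyl ring would give a step beyond the scatter. From the compounds shown here alone, it also remains open whether compound 2, compound 3 and compound 4 would separate at another concentration in this assay.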